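Iodo for Hydrogen on the Aromatic Ring of Compound 1

The source may hold more compounds than are shown below. What is called first, only, known or untested is meant among the compounds shown, and "the series" means these compounds.

Compound 1 `COC(=O)c1c(C)[nH]c(C)c1C(=O)c1ccccc1` gives 21900 nM in a functional assay with Cavia porcellus as the target (on this read-out lower numbers stand for an effect already at smaller amounts and higher numbers for an effect only at larger amounts of compound), the higher of the two numbers on record, while compound 2 `COC(=O)c1c(C(=O)c2ccccc2Cc2ccccc2)c[nH]c1C` gives 460 nM in this assay, a much lower number whose gap to compound 1 lies beyond the scatter. Compound 3 `COC(=O)c1c(C)[nH]c(C)c1C(=O)c1ccccc1I` differs from compound 1 by iodo in place of hydrogen on an aromatic carbon. Among the compounds with values here, since no step of this kind has been measured, only compound 1 at 21900 nM anchors the expectation. The step expected is a 3.7-fold lower number from compound 1 to compound 3 (0.56 log units; beyond the scatter), a modest move toward lower numbers. Compound 3 is therefore estimated at about 6000 nM, between 1200 nM and 25000 nM.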

Compound 3, half-maximal effective concentration: 5900 nM
The estimate for compound 3 lay 1.0-fold (0.01 log units) above the measured number; the measured number falls inside the stated range.
By their numbers in this assay, from the lowest: compound 2; then compound 3; then compound 1.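

Within the data shown here, on this assay, the aromatic carbon ortho to a large group accepts a change: a single iodine atom in place of hydrogen gives a 3.7-fold lower number from compound 1 to compound 3 (0.57 log units; beyond the scatter) and so provides the only one-place comparison on record, showing that this carbon affects the read-out. Nothing on record explains the step. Still open, on these data alone, is whether fluoro, chloro, methoxy or an amine on this same carbon would move the number as iodo does. Also open, as far as these compounds go, is whether iodo would do the same on another carbon of this ring.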